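A Single Methyl on the Carboxymethyl Arm

The source may report more compounds than this note shows. Statements on the series, on what has been measured and on what is new or still open speak of the compounds shown alone.

Measured compounds:
Compound 1 `O=C(O)CNC(=O)[C@]1(O)C[C@@H](O)[C@@H](O)[C@H](O)C1` — in an assay on HL-60 cells for inhibition of P-selectin (Homo sapiens) (on this read-out lower numbers stand for stronger inhibition and higher numbers for weaker inhibition), compound 1 gives > 50000000 nM, which is a limit of the assay and not a number.
Compound 2 `O=C(O)CCCNC(=O)[C@]1(O)C[C@@H](O)[C@@H](O)[C@H](O)C1` — compound 2 gives 40000000 nM.
Compound 3 `O=C(O)CC[C@H](NC(=O)[C@]1(O)C[C@@H](O)[C@@H](O)[C@H](O)C1)C(=O)O` — compound 3 gives 21000000 nM.

Compound 1 therefore stands at the upper edge of what this assay reports (the limit of > 50000000 nM in this assay, at which 1 of the 3 values shown sits); only a limit is known for it, and all three measured values sit at the weak end of the series. Both measured steps away from compound 1 lower the number: an at least 1.2-fold lower number from compound 1 to compound 2 (0.09 log units; that floor lies within the scatter), and an at least 2.3-fold lower number from compound 1 to compound 3 (0.37 log units; beyond the scatter). Between the two numbered compounds, a 1.9-fold lower number from compound 2 to compound 3 (0.28 log units; within the scatter).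

Compound 4 `C[C@H](NC(=O)[C@]1(O)C[C@@H](O)[C@@H](O)[C@H](O)C1)C(=O)O` differs from compound 1 by methyl in place of hydrogen on a saturated chain carbon bound to an amide-type nitrogen and a carbonyl carbon. The two steps from compound 1 both introduce a 2-carboxyethyl, a change far larger than a methyl, so they bear on compound 4 only loosely, and the smaller of them lay within the scatter. The step from compound 1 to compound 4 is thus expected to be a number no higher from compound 1 to compound 4 (the limit leaves the size open), with no direction that should stand out beyond the scatter. Compound 4 is estimated to give about 50000000 nM, between 20000000 nM and 120000000 nM, and this assay may well return only a limit for it again.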

Compound 4, half-maximal inhibitory concentration: > 50000000 nM
Compound 4 gave a limit, no number (the forecaster's own chance of this, stated with the estimate: 60%); the middle value lies on the limit itself.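

Compound 4, like compound 1, stands at a limit of the assay and not at a number, so the step between these two cannot be read, and a methyl in place of hydrogen at this position gives no measurable shift in this assay: the limit of > 50000000 nM in this assay, at which 2 of the 4 values shown sit.

The readable comparison comes from compound 3, where hydrogen in place of carboxymethyl, on a saturated chain carbon two bonds along the chain from an amide-type nitrogen and a carbonyl carbon, gives an at least 2.3-fold higher number from compound 3 to compound 4 (0.37 log units; beyond the scatter) and so separates the methyl-bearing arm from the arm with the second carboxy group. The other comparison, 1-carboxyethyl in place of 3-carboxypropyl on an amide-type nitrogen, gives an at least 1.2-fold higher number from compound 2 to compound 4 (0.09 log units; that floor lies within the scatter) and its floor stays inside the scatter, so it does not separate these two arms.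

The compounds shown leave open how far past its limit compound 4 lies, and so what the methyl itself contributes. They also leave open whether an amine, a hydroxymethyl or a longer chain ending in a carboxylic acid on this same carbon would match the number seen for compound 3.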